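From Phenyl to 2,4-Dichlorophenyl in a Weak Growth Inhibitor

The source may report more compounds than this note shows. Statements on the series, on what has been measured and on what is new or still open speak of the compounds shown alone.

Among the measured compounds shown here, in a functional assay on MCF7 cells (Homo sapiens) for inhibition, read by sulforhodamine B assay, with a stated time of 48 h (a lower number here means a stronger inhibitor of growth, a higher number a weaker inhibitor of growth), compound 1 (`O=C(Cc1csc2nc(-c3ccc(Br)cc3)cn12)N/N=C/c1ccccc1`) gives 75900 nM and so holds the higher of the two numbers measured so far. Compound 2 (`O=C(Cc1csc2nc(-c3ccc(Br)cc3)cn12)N/N=C/c1ccccc1O`) has a hydroxy in place of hydrogen on an aromatic carbon and gives 13200 nM in the same test. That single change is a 5.8-fold lower number from compound 1 to compound 2 (0.76 log units; beyond the scatter) and counts as a modest move. Compound 3 (`O=C(Cc1csc2nc(-c3ccc(Br)cc3)cn12)N/N=C/c1ccc(Cl)cc1Cl`) has not yet been measured. It differs from compound 1 by one change, 2,4-dichlorophenyl in place of phenyl on a carbon with a double bond to nitrogen. For the measured compounds named here, the hydroxy step is the only measured guide, and it touches the same ring. Going by the values given here, it shows that a change on this ring can shift the number, yet no compound with chlorine has been measured, so the direction remains a judgement. A modest move towards a lower number seems most likely, and the estimate is a 2.5-fold lower number from compound 1 to compound 3 (0.40 log units; beyond the scatter) with real doubt about its size. Compound 3 is estimated at 30000 nM in this assay with a range of 9000 nM to 90000 nM expected.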

Compound 3, concentration for 50% growth inhibition: < 100000 nM
Compound 3 gave a limit, no number; the forecaster's own chance of this, stated with the estimate: 10%; the middle value is on the limit's open side.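

In this assay compound 3 gives < 100000 nM, which is a limit and not a number. The steps to compound 3 from compound 1 and from compound 2 therefore cannot be read. The compounds shown leave open whether 2,4-dichlorophenyl in place of phenyl raises or lowers the number, and by how much.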